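A few compounds are considered here, and "the series" means these few. Any claim that something is new, unique, unknown or untested is made for them only; others in the source may bear on it.

For the measured compounds named here, in a functional assay on SGC-7901 cells (Homo sapiens) for antiproliferative activity, read by MTT assay, with a stated time of 72 h (on this read-out lower numbers stand for stronger inhibition and higher numbers for weaker inhibition), compound 2 `COc1ccc(-c2ssc(=S)c2-c2cc(OC)c(OC)c(OC)c2)cc1O` gives 271 nM, the lower of the two numbers measured so far, while compound 1 `COc1ccc(-c2ssc(=S)c2-c2cc(OC)c(OC)c(OC)c2)cc1` gives 21100 nM. Compound 3 `COc1ccc(-c2ssc(=S)c2-c2cc(OC)c(OC)c(OC)c2)cc1[N+](=O)[O-]` has nitro in place of hydroxy on an aromatic carbon, ortho to a methoxy group (nitro in place of hydroxy on an aromatic carbon). Going by the values given here, the only measured step bearing on this change is a 78-fold lower number from compound 1 to compound 2 (1.89 log units; beyond the scatter), large and beyond the scatter, where hydroxy replaced hydrogen on that same carbon. Among the compounds with values here, no nitro compound has been measured, so the guide is weak, but with the hydroxy gone a large move in this assay to a higher number is expected, part of the way back towards compound 1 at 21100 nM. The expected change is an 11-fold higher number from compound 2 to compound 3 (1.04 log units; beyond the scatter). Compound 3 is estimated at 3000 nM, within a range from 500 nM to 18000 nM.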

Compound 3, half-maximal inhibitory concentration: 13600 nM
Estimate against measurement, compound 3: 4.5-fold (0.66 log units) below, within the range that was stated.
By their numbers in this assay, from the lowest: compound 2; then compounds 3 and 1 (each within the scatter of the next).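

In this assay the gain at this carbon does not survive the swap to nitro: there is a 50-fold higher number from compound 2 to compound 3 (1.70 log units; beyond the scatter) and the result lands level with the unsubstituted compound, with a 1.6-fold lower number from compound 1 to compound 3 (0.19 log units; within the scatter) lying within the scatter. Of the three groups seen on this carbon, only hydroxy stands apart, while nitro and hydrogen cannot be told apart. Nothing available explains why hydroxy behaves differently here.

On these data alone, whether an amine or a fluorine on this carbon would side with hydroxy or with nitro and hydrogen stays open.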